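A few compounds are considered here, and "the series" means these few. Any claim that something is new, unique, unknown or untested is made for them only; others in the source may bear on it.

Working notes on the sulfonamide series. Compound 1 `COc1ccc(NS(=O)(=O)c2cc(I)ccc2C)cc1N1CCN(C)CC1` and compound 2 `COc1ccc(NS(=O)(=O)c2ccccc2)cc1N1CCN(C)CC1` share one core and differ only at the sulfonyl sulfur. Among the measured compounds shown here, in an assay on HeLa cells for binding affinity to 5-hydroxytryptamine receptor 6 (Homo sapiens) (a lower number here means a stronger inhibitor, a higher number a weaker inhibitor), compound 1 gives 1 nM, and in the same assay compound 2 gives 10 nM, the highest of the two numbers so far; the step of a 10-fold higher number from compound 1 to compound 2 (1.00 log units; beyond the scatter) is the only measured comparison available.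

Compound 3 `COc1ccc(NS(=O)(=O)c2cn(C)cn2)cc1N1CCN(C)CC1` is the next point: 1-methyl-1H-imidazol-4-yl in place of phenyl on a sulfonyl sulfur. For the measured compounds named here, no measured step speaks to swapping the six-membered ring of carbon only for a five-membered aromatic ring with 2 hetero atoms; the single measured step, a 10-fold higher number from compound 1 to compound 2 (1.00 log units; beyond the scatter), changes substituents on the phenyl rather than the ring itself, so it sets no direction here. With the unsubstituted phenyl of compound 2 already the weakest point, a further loss is expected, of moderate size: an estimated step of a 4.0-fold higher number from compound 2 to compound 3 (0.60 log units; beyond the scatter). Compound 3 is expected to give about 40 nM in this assay, within 10 nM to 160 nM.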

Compound 3, inhibition constant: 794 nM
Estimate against measurement, compound 3: 20-fold (1.30 log units) below; measured number outside the range, above it.
By their numbers in this assay, from the lowest: compound 1; then compound 2; then compound 3.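

Changing the ring itself on the sulfonyl sulfur moves the number further than removing the substituents from the phenyl did: in this assay, 1-methyl-1H-imidazol-4-yl in place of phenyl gives a 79-fold higher number from compound 2 to compound 3 (1.90 log units; beyond the scatter) against the modest earlier step. Measured against the 5-iodo-2-methylphenyl group, the same ring gives a 790-fold higher number from compound 1 to compound 3 (2.90 log units; beyond the scatter) and is the largest step among the three compounds. This position is therefore not limited to small effects, and among these three compounds the five-membered aromatic ring with 2 hetero atoms stands highest.

These compounds do not separate the contribution of the ring nitrogens from that of the methyl on the imidazole, and they leave open how an amine or a carboxylic acid on the phenyl would behave at this position. Nothing available explains the size of this step.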